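The source may hold more compounds than are shown below. What is called first, only, known or untested is meant among the compounds shown, and "the series" means these compounds.

Of the compounds shown here, three built on a shared core have been measured in a functional assay on MCF7 cells (Homo sapiens) for cytotoxicity, read by MTT assay, with a stated time of 72 h; on this read-out higher numbers stand for weaker inhibition and lower numbers for stronger inhibition. Compound 1 `CCNC(=O)N1CCN(C(=S)SCc2cn(Cc3ccccc3F)nn2)CC1` gives 5760 nM, and compound 2 `CCNC(=O)N1CCN(C(=S)SCc2cn(Cc3ccc(F)cc3)nn2)CC1` gives 3660 nM, a change of a 1.6-fold lower number from compound 1 to compound 2 (0.20 log units; within the scatter). Compound 3 `NC(=O)N1CCN(C(=S)SCc2cn(Cc3ccc(Cl)cc3)nn2)CC1` shows only a limit, > 128000 nM, which is the limit of > 128000 nM in this assay, at which 1 of the 3 values shown sits. Compound 4 `CCNC(=O)N1CCN(C(=S)SCc2cn(Cc3ccc(Cl)cc3)nn2)CC1` differs from compound 3 by ethyl in place of hydrogen on an amide-type nitrogen. For the measured compounds named here, no measured step alters this amide-type nitrogen on its own, so the single measured step, which concerns the ring, does not bear on it directly; what the numbers do show is that compound 1 and compound 2, both carrying the ethyl group, give values where compound 3 gives none. Compound 4 is therefore expected to give a value, a step of an at least 25-fold lower number from compound 3 to compound 4 (1.40 log units; beyond the scatter). The estimate for compound 4 is 5000 nM, between 1500 nM and 25000 nM.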

Compound 4, half-maximal inhibitory concentration: > 128000 nM
Compound 4: only a limit was reported (the forecaster's own chance of this, stated with the estimate: 15%); middle value at least 25-fold (1.40 log units) away from the limit.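

In this assay, the chloro group now matters: chloro in place of fluoro on an aromatic carbon gives an at least 34-fold higher number from compound 2 to compound 4 (1.54 log units; beyond the scatter), and 4-chlorophenyl in place of 2-fluorophenyl gives an at least 22-fold higher number from compound 1 to compound 4 (1.34 log units; beyond the scatter), both large steps, whereas the earlier change from 2-fluorophenyl to 4-fluorophenyl stayed within the scatter. Ethyl on the amide-type nitrogen therefore does not by itself secure a readable value, and the step between compound 3 and compound 4 cannot be read, since both are limits: the limit of > 128000 nM in this assay, at which 2 of the 4 values shown sit.

As far as these compounds go, whether bromo or methyl in place of chloro on that aromatic carbon would give a readable value stays open. So does whether 2-chlorophenyl would behave like 4-chlorophenyl.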